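The source may report more compounds than this note shows. Statements on the series, on what has been measured and on what is new or still open speak of the compounds shown alone.

Of the compounds shown here, two sharing one core have so far been tested in an ADME assay on microsomes from liver (Mus musculus) for metabolic stability; a lower number here means slower removal, a higher number faster removal of the compound. Compound 1 `O=C1CCCN1Cc1n[nH]c(-c2ncc3cccnc3c2O)n1` reads < 0.5 mL.min-1.g-1, which is a limit of the assay and not a number. Among the compounds with values here, compound 2 `CNc1ccnc2c(O)c(-c3nc(C)n[nH]3)ncc12` gives 3.1 mL.min-1.g-1, so it holds the only true number in the set, and there is no series against which to rank it. The next compound keeps the methyl-bearing five-membered substituent of compound 2 and alters a single place. Compound 3 `COc1ccccc1-c1ccnc2c(O)c(-c3nc(C)n[nH]3)ncc12` carries 2-methoxyphenyl in place of methylamino on an aromatic carbon, opposite the ring nitrogen (2-methoxyphenyl in place of methylamino on an aromatic carbon). Within the data shown here, no measured pair in this set shows what such a replacement does in this assay, so any forecast rests on the size of the change and on the starting point of compound 2 at 3.1 mL.min-1.g-1. The expectation is a move towards faster removal, and the estimated 3.2-fold higher number from compound 2 to compound 3 (0.51 log units; beyond the scatter) would lie beyond the usual scatter, though with wide uncertainty. Compound 3 is expected to read about 10 mL.min-1.g-1, within an estimated range of 3 mL.min-1.g-1 to 30 mL.min-1.g-1.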

Compound 3, intrinsic clearance in microsomes: 0.8 mL.min-1.g-1
Compound 3: middle estimate off by 13-fold (1.10 log units), on the high side, and the stated range ends above it.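

In this assay, within the data shown here, 2-methoxyphenyl in place of methylamino on an aromatic carbon, opposite the ring nitrogen, gives a 3.9-fold lower number from compound 2 to compound 3 (0.59 log units; beyond the scatter), the first step in this set that can be read. This position therefore takes a group of 8 heavy atoms, with a six-membered aromatic ring of carbon only, in place of one of 2 heavy atoms, and the number goes down rather than up. The step also exchanges a group with 1 hydrogen-bond donor for one with 0, so the ring, the methoxy group and the loss of the donor all change together, and this single step cannot tell them apart.

Left open is which of these changes carries the step, a question that a plain phenyl or a dimethylamino group in the same place would bear on. It is also unclear how far a lower number could be read at this position, since compound 1 sits at a limit of the assay and gives no number: the limit of < 0.5 mL.min-1.g-1 in this assay, at which 1 of the 3 values shown sits.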